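The source may hold more compounds than are shown below. What is called first, only, known or untested is meant among the compounds shown, and "the series" means these compounds.

Measured so far:
Compound 1 `CC(C(=O)NCc1ccc(C(F)(F)F)nc1Nc1ccc(F)cc1)c1ccc(NS(C)(=O)=O)c(F)c1`: 39.2 nM
Compound 2 `CC(C(=O)NCc1ccc(C(F)(F)F)nc1N1CCC(Cc2cc(F)cc(F)c2)CC1)c1ccc(NS(C)(=O)=O)c(F)c1`: 0.4 nM

Of the compounds shown here, two sharing a common core have been measured in a functional assay on CHO-K1 cells for antagonist activity at transient receptor potential cation channel subfamily V member 1 (Homo sapiens), read by FLIPR; on this read-out lower numbers stand for stronger inhibition and higher numbers for weaker inhibition. Compound 1 gives 39.2 nM, the higher of the two numbers. Compound 2 gives 0.4 nM, a number far lower than that of compound 1 and well outside the usual scatter, which marks compound 1 as the weaker of the pair.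

Compound 3 `CC(C(=O)NCc1ccc(C(F)(F)F)nc1N1CCCCCCC1)c1ccc(NS(C)(=O)=O)c(F)c1` has not yet been measured. It differs from compound 1 in one place: a group of 8 heavy atoms (7 carbon, 1 nitrogen; one eight-membered non-aromatic ring with 1 hetero atom) in place of a group of 8 heavy atoms (6 carbon, 1 nitrogen, 1 fluorine; one six-membered aromatic ring of carbon only), on an aromatic carbon

Within the data shown here, no single-change step between measured compounds is available to guide this change directly. Compound 2, the only other reference, shows that a saturated ring attached at this position of the core is compatible with a very low number. On that basis compound 3 is expected to give a lower number than compound 1, with an expected step of a 6.5-fold lower number from compound 1 to compound 3 (0.82 log units; beyond the scatter), beyond the scatter but smaller than the gap between compound 1 and compound 2. The estimate for compound 3 in this assay is 6 nM, within a range from 1.5 nM to 25 nM.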

Compound 3, inhibition constant: 0.7 nM
The estimate for compound 3 lay 8.6-fold (0.93 log units) above the measured number; measured number outside the range, below it.
By their numbers in this assay, from the lowest: compounds 2 and 3 (each within the scatter of the next); then compound 1.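

In this assay, placing the eight-membered non-aromatic ring with 1 hetero atom on the aromatic carbon next to the ring nitrogen, in place of (4-fluorophenyl)amino, gives a 56-fold lower number from compound 1 to compound 3 (1.75 log units; beyond the scatter). Among these compounds, this is the first direct comparison at this position, and it shows that the position responds strongly to this change, even though both groups have the same count of heavy atoms. The entering group has 0 hydrogen-bond donors where the leaving group has 1, yet no evidence at hand links this or any other difference to the size of the step.

As far as these compounds go, this single step changes the ring and the amino hydrogen together, so their separate contributions stay open. From the compounds shown here alone, it also remains open whether a pyrrolidine, an unsubstituted piperidine or an open-chain diethylamino group at this position would give a similarly low number.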